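Cytotoxicity notes on a chromone series in MT4 cells

The source may hold more compounds than are shown below. What is called first, only, known or untested is meant among the compounds shown, and "the series" means these compounds.

Measured compounds:
- compound 1, `CC(=O)Nc1ccc2oc(-c3ccc(F)cc3)cc(=O)c2c1`: 203000 nM
- compound 2, `CC(=O)Nc1ccc2oc(-c3ccc(C(F)(F)F)cc3)cc(=O)c2c1`: 330000 nM
- compound 3, `Nc1ccc2oc(-c3ccc(F)cc3)c(O)c(=O)c2c1`: 92600 nM

All three values come from an ADME assay on MT4 cells (Homo sapiens) for cytotoxicity, read by MTT assay, with a stated time of 4 days; a higher number here means that more compound is tolerated, a lower number that less compound is tolerated. Compound 1 and compound 2 share one core and differ only by trifluoromethyl in place of fluoro on an aromatic carbon; the step of a 1.6-fold higher number from compound 1 to compound 2 (0.21 log units; within the scatter) is small, so the two values are treated as equivalent here. Compound 3 carries a different core; the difference between the two cores is not broken down here. In this assay compound 3 stands lowest of the three, beyond the scatter against both compound 1 and compound 2, so less of it is tolerated.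

Compound 4, `Nc1ccc2oc(-c3ccc(C(F)(F)F)cc3)c(O)c(=O)c2c1`, has not yet been measured. It differs from compound 3 by trifluoromethyl in place of fluoro on an aromatic carbon, which is the same change as that from compound 1 to compound 2, on the same place. The expectation rests on that earlier step: because a 1.6-fold higher number from compound 1 to compound 2 (0.21 log units; within the scatter) sat within the scatter, the step of a 1.4-fold higher number from compound 3 to compound 4 (0.15 log units; within the scatter) is expected to be of similar size, and for compound 4 a value near 130000 nM is estimated.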

Compound 4, half-maximal cytotoxic concentration: 3900 nM
Beside the measured number, compound 4's estimate is 33-fold (1.52 log units) above it; the measured number lies below the stated range.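

In this assay trifluoromethyl in place of fluoro on an aromatic carbon gives a 24-fold lower number from compound 3 to compound 4 (1.38 log units; beyond the scatter) on the core of compound 3, so much less of compound 4 is tolerated. The same change does not give a comparable step on the two cores, so a step read on one of them cannot simply be carried to the other in this series: the same change on two cores in this assay, a 1.6-fold higher number (0.21 log units; within the scatter) from compound 1 to compound 2 and a 24-fold lower number (1.38 log units; beyond the scatter) from compound 3 to compound 4, 39-fold (1.59 log units) apart, beyond the scatter of two such steps. This rests on a single pair per core and does not show which difference between the two cores lies behind the gap, nor how the change would behave on any further core.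

Open, on these data alone, is whether the hydroxyl group, the free amine or the two together set the core of compound 3 apart from the core of compound 1 in this respect. Also open, as far as these compounds go, is how other groups in the same place, such as chloro, methoxy or nitrile, would behave on each core.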